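Cytotoxicity at the limit across amide side-chain variants

This account rests on a few compounds, and the source may have more. Where it says the series, first, only, none or still open, it means among the compounds named here.

Three members of the series have been tested in an ADME assay on MT2 cells (Homo sapiens) for cytotoxicity; a lower number here means that less compound is tolerated, a higher number that more compound is tolerated. Compound 1 `Cc1nc2cc(C(=O)NCc3ccc(F)cc3S(C)(=O)=O)nn2c(-c2cc(F)c3c(c2C)CCCO3)c1[C@H](OC(C)(C)C)C(=O)O` carries a 4-fluoro-2-(methylsulfonyl)phenyl group on the saturated chain carbon bound to the amide-type nitrogen; in this assay compound 1 reaches only the limit > 40000 nM. Compound 2 `CCCNC(=O)c1cc2nc(C)c([C@H](OC(C)(C)C)C(=O)O)c(-c3cc(F)c4c(c3C)CCCO4)n2n1` has ethyl in its place, and in this assay compound 2 also gives only the limit > 40000 nM. Compound 3 `Cc1nc2cc(C(=O)NCCC(C)C)nn2c(-c2cc(F)c3c(c2C)CCCO3)c1[C@H](OC(C)(C)C)C(=O)O` carries isobutyl there, and in this assay compound 3 likewise returns the limit > 40000 nM. Compound 3 therefore stands where all three values stand, at the limit of > 40000 nM in this assay, at which 3 of the 3 values shown sit. The steps a step that the two limits leave unreadable from compound 1 to compound 2, a step that the two limits leave unreadable from compound 1 to compound 3 and a step that the two limits leave unreadable from compound 2 to compound 3 are all unreadable, since both ends sit at a limit.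

Compound 4 `Cc1nc2cc(C(=O)NCCC3CCOCC3)nn2c(-c2cc(F)c3c(c2C)CCCO3)c1[C@H](OC(C)(C)C)C(=O)O` differs from compound 3 by oxan-4-yl in place of isopropyl on a saturated chain carbon, two bonds along the chain from an amide-type nitrogen. For the measured compounds named here, the steps that bear on it, from compound 1 and compound 2 to compound 3, all lie between limits and so give no readable size; none of the three side chains tried has pulled a value below the limit. Compound 4 is therefore expected to sit at the limit as well, with an expected step of a number no higher from compound 3 to compound 4 (the limit leaves the size open) of none beyond the scatter. The estimate for compound 4 in this assay is 40000 nM, in the range 25000 nM to 80000 nM.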

Compound 4, half-maximal cytotoxic concentration: > 40000 nM
Compound 4: a limit, no number; the forecaster's own chance of this, stated with the estimate: 85%; the middle value sits exactly at the limit.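

In this assay compound 4 gives only a limit, > 40000 nM. The steps to compound 4 from compound 1, compound 2 and compound 3 cannot be read, since both ends of each sit at a limit: the limit of > 40000 nM in this assay, at which 4 of the 4 values shown sit.

The compounds shown leave open how far any of these amide side chains lies from that limit, and whether they differ at all.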